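This account rests on a few compounds, and the source may have more. Where it says the series, first, only, none or still open, it means among the compounds named here.

Of the compounds shown here, three built on one shared core have been measured in a functional assay on HEp-2 cells (Homo sapiens) for inhibition; a higher number here means a weaker inhibitor, a lower number a stronger inhibitor. Compound 1 `CC(=O)OCCOn1cnc2c(Cl)nc(I)nc21` gives 56200 nM in this assay. For compound 2 `CC(O)n1cnc2c(Cl)nc(I)nc21` this assay reports only a limit, > 500000 nM. For compound 3 `CC(O)n1cnc2c(N)nc(I)nc21` this assay likewise reports only a limit, > 500000 nM. Compound 3 therefore stands at the edge of what this assay can resolve, and the step that the two limits leave unreadable from compound 2 to compound 3 cannot be read, because both of its ends sit at the limit of > 500000 nM in this assay, at which 2 of the 3 values shown sit.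

Compound 4 `Nc1nc(I)nc2c1ncn2OCCO` has not yet been measured. It differs from compound 3 in one place: 2-hydroxyethoxy in place of 1-hydroxyethyl on an aromatic nitrogen. Among the measured compounds shown here, no measured step touches this group, so nothing read so far tells how large a change to expect or in which direction. For the measured compounds named here, the only numerical value shown belongs to compound 1, which carries a different chain on the ring nitrogen and chloro rather than amino on the core. The expected step in this assay is an at least 2.0-fold lower number from compound 3 to compound 4 (0.30 log units; that floor lies within the scatter), a guess rather than a reading. Compound 4 is thus expected to give about 250000 nM in this assay, somewhere between 40000 nM and 500000 nM, with a real chance that only a limit is reported again.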

Compound 4, half-maximal inhibitory concentration: > 500000 nM
Compound 4: only a limit was reported; the forecaster's own chance of this, stated with the estimate: 55%; at least 2.0-fold (0.30 log units) between middle value and limit.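

Compound 4, like compound 3, gives only a limit in this assay, so the step between them cannot be read: the limit of > 500000 nM in this assay, at which 3 of the 4 values shown sit.

The compounds shown leave open whether 2-hydroxyethoxy and 1-hydroxyethyl on the aromatic nitrogen differ at all in strength of inhibition, and likewise amino and chloro on the core.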